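A few compounds are considered here, and "the series" means these few. Any claim that something is new, unique, unknown or untested is made for them only; others in the source may bear on it.

Compound 1 `CCOC(=O)c1cnc(C)nc1NN1C(=O)C=C(C)C1=O`: 16000 nM
Compound 2 `CCOC(=O)c1cnc(-c2cccc(Br)c2)nc1NN1C(=O)C=C(C)C1=O`: 700 nM

Going by the values given here, of the two measured compounds, compound 2 stands lowest in a functional assay on Jurkat cells for inhibition of nuclear factor NF-kappa-B complex (Homo sapiens); on this read-out higher numbers stand for weaker inhibition and lower numbers for stronger inhibition; the step of a 23-fold lower number from compound 1 to compound 2 (1.36 log units; beyond the scatter) separates it from compound 1, its only neighbour. Compound 3 `CCOC(=O)c1cnc(CC2=CCCCC2)nc1NN1C(=O)C=C(C)C1=O` has not yet been measured. It differs from compound 2 in one place: (cyclohex-1-en-1-yl)methyl in place of 3-bromophenyl on an aromatic carbon. Among the compounds with values here, only one measured step bears on this position, and it was large: the step of a 23-fold lower number from compound 1 to compound 2 (1.36 log units; beyond the scatter) showed that replacing methyl by 3-bromophenyl at this carbon lowered the number considerably. Within the data shown here, compound 3 keeps a group of the same heavy-atom count at that carbon but exchanges the aromatic ring for a non-aromatic one with a one-carbon link, a change for which no measured pair gives guidance. Compound 3 is therefore expected to fall between the two measured numbers, with an expected step of a 4.3-fold higher number from compound 2 to compound 3 (0.63 log units; beyond the scatter). The estimate for compound 3 in this assay is 3000 nM, within a range from 700 nM to 12000 nM.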

Compound 3, half-maximal inhibitory concentration: 2000 nM
Compound 3: the middle estimate sits 1.5-fold (0.18 log units) above what was measured, within the range that was stated.
By their numbers in this assay, from the lowest: compound 2; then compound 3; then compound 1.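

In this assay compound 3 shows that an aromatic ring is not needed at this carbon for a large part of the drop: an 8.0-fold lower number from compound 1 to compound 3 (0.90 log units; beyond the scatter) comes with a non-aromatic ring on a one-carbon link in place of the aromatic group. The exchange is not neutral, however, as a 2.9-fold higher number from compound 2 to compound 3 (0.46 log units; beyond the scatter) follows when (cyclohex-1-en-1-yl)methyl replaces 3-bromophenyl, although both groups hold the same count of heavy atoms. Nothing available accounts for this difference.

Going by these compounds, what an unsubstituted phenyl, a benzyl or a saturated cyclohexylmethyl group would give at this carbon stays open, so the separate shares of the bromine, the one-carbon link and the double bond cannot be told apart. The compounds shown also leave open how an amine or a carboxylic acid would read here.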